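Methyl for methoxy on the pyrimidine of compound 1

The compounds below may be only part of what the source reports. "The series", "measured", "known", "first", "only" and "open" are said of these compounds alone.

Measured compounds:
- compound 1, `COc1cc(SC)nc(NC(=S)NC(=O)c2c(-c3ccc(Cl)cc3Cl)noc2C)n1`, -8.31%
- compound 2, `COc1cc(Cl)nc2n/c(=N/C(=O)c3c(-c4ccc(Cl)cc4Cl)noc3C)sn12`, 19.3%
- compound 3, `COc1cc(C)nc2n/c(=N/C(=O)c3c(-c4ccc(Cl)cc4Cl)noc3C)sn12`, 45.7%

In a functional assay on the whole organism for inhibition, with Chenopodium ficifolium as the target, with a stated time of 72 h, tested at 10 mg/L (on this read-out higher numbers stand for more inhibition of growth at the one concentration tested and lower numbers for less inhibition of growth), compound 1 gives -8.31%, the lowest of the three numbers; compound 2 lies closest to it, and compound 3 furthest, both beyond the scatter. Compound 4, `CSc1cc(C)nc(NC(=S)NC(=O)c2c(-c3ccc(Cl)cc3Cl)noc2C)n1`, has not yet been measured. It differs from compound 1 in one place: methyl in place of methoxy on an aromatic carbon.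

Among the compounds with values here, only one measured step exists, a number 26.4 percentage points higher from compound 2 to compound 3 (beyond the scatter). That step swaps chloro for methyl on a core that is not the core of compound 1, and the group that leaves is not methoxy, so it bears on the change to compound 4 only loosely. It does show that a change of a small group on that ring can shift the read-out by a modest amount in the upward direction. Within the data shown here, no measured pair shows methyl in place of methoxy on the core of compound 1.

The account therefore expects for compound 4 a small rise, a number 14.3 percentage points higher from compound 1 to compound 4 (beyond the scatter), which may or may not clear the scatter. Compound 4 is estimated at 6%, within a range from -14% to 30%.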

Compound 4, percent growth inhibition at one concentration: 32.8%
Compound 4: the middle estimate sits 26.8 percentage points below what was measured; measured number outside the range, above it.
By their numbers in this assay, from the lowest: compound 1; then compound 2; then compound 4; then compound 3.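

In this assay, within the data shown here, the step on the core of compound 1, a number 41.1 percentage points higher from compound 1 to compound 4 (beyond the scatter), shows that this aromatic carbon of the six-membered ring with 2 nitrogen matters to growth inhibition, a point the earlier compounds could not make, since neither of them changes methoxy or carries this core with a change at this place. Together with a number 26.4 percentage points higher from compound 2 to compound 3 (beyond the scatter), it gives two measured steps in which methyl enters and the number goes up, although the group that leaves and the core both differ between the two, so the two steps share only the entering group. No measurement here accounts for the rise from methoxy to methyl on this ring.

The compounds shown leave open whether the gain comes from losing methoxy or from gaining methyl, which a bare hydrogen, an ethyl chain or an amine at this carbon on the core of compound 1 could help to separate. They also leave open whether the same exchange would give a rise on the other core, where the methoxy group stays in place in compound 2 and compound 3.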